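The source may report more compounds than this note shows. Statements on the series, on what has been measured and on what is new or still open speak of the compounds shown alone.

Measured compounds:
compound 1, `Cc1n[nH]c(C(=O)O)c1Cc1cccc(-c2ccc(C#N)cc2)c1`: 300 nM
compound 2, `Cc1n[nH]c(C(=O)O)c1Cc1cccc(C(N)=O)c1`: 900 nM
compound 3, `Cc1n[nH]c(C(=O)O)c1Cc1ccc(-c2ccc(OC(F)(F)F)cc2)cc1`: 2000 nM

All three values come from an assay on isolated protein for inhibition of 2-Hydroxyacid oxidase 2 (Rattus norvegicus); on this read-out higher numbers stand for weaker inhibition and lower numbers for stronger inhibition. Compound 2 sits second highest of the three numbers; its nearest neighbour is compound 3, and its furthest is compound 1. For the measured compounds named here, the one single-point step among the measured compounds is a 3.0-fold higher number from compound 1 to compound 2 (0.48 log units; beyond the scatter), a modest weakening that lies beyond the scatter. Going by the values given here, no step between compound 2 and compound 3 is computed; the two values simply show compound 3 with the higher number.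

Compound 4, `Cc1n[nH]c(C(=O)O)c1Cc1cccc(C#N)c1`, is not yet measured in this assay. Its change from compound 2 is cyano in place of carbamoyl on an aromatic carbon of a six-membered aromatic ring of carbon only, meta to a large group. Among the compounds with values here, no measured step swaps these two groups on the same carbon, so the step from compound 1 to compound 2 bears only loosely: it shows that trimming the group at this carbon costs a modest amount of activity. On that basis a small shift toward a higher number, or none beyond the scatter, is expected for compound 4, as a 1.3-fold higher number from compound 2 to compound 4 (0.12 log units; within the scatter). Compound 4 is therefore estimated at 1200 nM, with a range from 400 nM to 3500 nM.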

Compound 4, half-maximal inhibitory concentration: 500 nM
Compound 4: middle estimate off by 2.4-fold (0.38 log units), on the high side; low and high end bracket the measured number.
By their numbers in this assay, from the lowest: compounds 1, 4 and 2 (each within the scatter of the next, the first and the last beyond it); then compound 3.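

At this aromatic carbon, meta to a large group, this assay gives a 1.8-fold lower number from compound 2 to compound 4 (0.26 log units; within the scatter) for cyano in place of carbamoyl, so this swap, which removes the hydrogen-bond donor and one heavy atom, does not separate the two groups. Cyano in place of 4-cyanophenyl gives a 1.7-fold higher number from compound 1 to compound 4 (0.22 log units; within the scatter), so the removal of the 4-cyanophenyl ring does not by itself carry a cost beyond the scatter, and the loose reading of a 3.0-fold higher number from compound 1 to compound 2 (0.48 log units; beyond the scatter) as a general penalty for a smaller group at this carbon does not hold for compound 4. Nothing available explains these values.

As far as these compounds go, whether the same flat reading extends to other groups at this carbon, such as an amine, a carboxylic acid or a longer chain, remains open, as the three compounds that differ here span only carbamoyl, cyano and 4-cyanophenyl. Compound 3 differs from the others in more than one place, so it gives no reading on this carbon, and the effect of its group on the shared core remains unresolved.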